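The source may report more compounds than this note shows. Statements on the series, on what has been measured and on what is new or still open speak of the compounds shown alone.

Three esters built on the same shared core have been tested in an ADME assay on HEK-293T cells (Homo sapiens) for cytotoxicity, read by MTT assay, with a stated time of 48 h; a higher number here means that more compound is tolerated, a lower number that less compound is tolerated. Compound 1 `CC1CCN(CC(=O)O[C@@H]2C[C@@H]3CC[C@@]2(C)C3(C)C)CC1` gives 71600 nM, compound 2 `CN1CCN(CC(=O)O[C@@H]2C[C@@H]3CC[C@@]2(C)C3(C)C)CC1` gives 313000 nM, and compound 3 `CN(C)CCC(=O)O[C@@H]1C[C@@H]2CC[C@@]1(C)C2(C)C` gives 505000 nM. Compound 3 thus has the highest number of the three, but its gap to compound 2 is within the scatter, whereas compound 1 sits further away: a 7.1-fold higher number from compound 1 to compound 3 (0.85 log units; beyond the scatter). The two other measured steps, which also change only the amine part of the side chain, are a 4.4-fold higher number from compound 1 to compound 2 (0.64 log units; beyond the scatter) and a 1.6-fold higher number from compound 2 to compound 3 (0.21 log units; within the scatter); exchanging one amine for another at this place has so far moved the number by a modest amount at most.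

Compound 4 `CCN(CC)CC(=O)O[C@@H]1C[C@@H]2CC[C@@]1(C)C2(C)C` differs from compound 3 by diethylamino in place of (dimethylamino)methyl on a saturated chain carbon bound to a carbonyl carbon. The step most like this one, a 1.6-fold higher number from compound 2 to compound 3 (0.21 log units; within the scatter), lay within the scatter, and only the exchange of 4-methylpiperidin-1-yl, a 7.1-fold higher number from compound 1 to compound 3 (0.85 log units; beyond the scatter), went beyond it. For compound 4 in this assay no step beyond the scatter is therefore expected, and the estimated step is a 1.3-fold lower number from compound 3 to compound 4 (0.10 log units; within the scatter). The expected value for compound 4 is 400000 nM, with a range from 150000 nM to 1000000 nM.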

Compound 4, half-maximal cytotoxic concentration: 344000 nM
Estimate against measurement, compound 4: 1.2-fold (0.07 log units) above, within the range that was stated.
By their numbers in this assay, from the lowest: compound 1; then compounds 2, 4 and 3 (each within the scatter of the next).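

Exchanging (dimethylamino)methyl for diethylamino, which can also be read as 2-(dimethylamino)ethyl to (diethylamino)methyl, gives a 1.5-fold lower number from compound 3 to compound 4 (0.17 log units; within the scatter), so in this assay this reshaping of the open-chain amine on a saturated chain carbon bound to a carbonyl carbon cannot be told apart from no change. The ring-bearing 4-methylpiperazin-1-yl also matches diethylamino, with a 1.1-fold higher number from compound 2 to compound 4 (0.04 log units; within the scatter), whereas 4-methylpiperidin-1-yl does not, with a 4.8-fold higher number from compound 1 to compound 4 (0.68 log units; beyond the scatter). Compound 1 now stands apart from all three other compounds, which makes 4-methylpiperidin-1-yl the only amine shown here with steps beyond the scatter, and no measurement at hand explains why.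

Going by these compounds, it remains open whether an unsubstituted piperidine, a morpholine or a primary amine at this place would group with compound 1 or with compounds 2, 3 and 4. The compounds shown also leave open what a carboxylic acid in place of the amine, or a longer chain carrying diethylamino, would do to the number in this assay.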